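Triterpenoid triazole esters: cytotoxicity toward lung cells

The source may hold more compounds than are shown below. What is called first, only, known or untested is meant among the compounds shown, and "the series" means these compounds.

This account follows a set of triterpenoid esters tested in an ADME assay on L132 cells (Homo sapiens) for cytotoxicity, read by MTT assay, with a stated time of 48 h; on this read-out higher numbers stand for weaker inhibition and lower numbers for stronger inhibition. Compound 1, `C/C(=C\CC/C(C)=C/CC[C@@H]1[C@@]2(C)CCC(=O)C(C)(C)[C@H]2CC[C@@]1(C)O)CC/C=C(\C)C(=O)OCc1cn(-c2ccc(F)c(Cl)c2)nn1`, carries a 3-chloro-4-fluorophenyl on the triazole nitrogen. In this assay compound 1 gives only a limit, > 150000 nM, and no number. Compound 2, `C/C(=C\CC/C(C)=C/CC[C@@H]1[C@@]2(C)CCC(=O)C(C)(C)[C@H]2CC[C@@]1(C)O)CC/C=C(\C)C(=O)OCc1cn(-c2ccc(Br)cc2)nn1`, also stops at a limit, > 150000 nM. The free acid, compound 3, `C/C(=C\CC/C(C)=C/CC[C@@H]1[C@@]2(C)CCC(=O)C(C)(C)[C@H]2CC[C@@]1(C)O)CC/C=C(\C)C(=O)O`, likewise reaches only the limit, > 150000 nM. Among the compounds with values here, the one step between measured neighbours, a step that the two limits leave unreadable from compound 1 to compound 2, therefore cannot be read, and compound 1 stands at the same limit as every other value shown, as the limit of > 150000 nM in this assay, at which 3 of the 3 values shown sit, records.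

Compound 4, `C/C(=C\CC/C(C)=C/CC[C@@H]1[C@@]2(C)CCC(=O)C(C)(C)[C@H]2CC[C@@]1(C)O)CC/C=C(\C)C(=O)OCc1cn(-c2cccc(Br)c2)nn1`, differs from compound 1 in one place: 3-bromophenyl in place of 3-chloro-4-fluorophenyl on an aromatic nitrogen. Within the data shown here, the only step that bears on this change is a step that the two limits leave unreadable from compound 1 to compound 2, which is unreadable, so no direction and no size beyond the scatter can be drawn from it. Since every measured value sits at the limit, the expectation for this assay is that compound 4 will also be reported as a limit rather than a number, and the step that the limit leaves unreadable from compound 1 to compound 4 is expected to be unreadable in the same way. Compound 4 is therefore estimated at 200000 nM, within 100000 nM to 600000 nM.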

Compound 4, half-maximal inhibitory concentration: > 150000 nM
Compound 4: a limit, no number (the forecaster's own chance of this, stated with the estimate: 85%); the middle value is on the limit's open side.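

In this assay compound 4 gives > 150000 nM, which is a limit and not a number. Within the data shown here, no step among compound 1, compound 2 and compound 4 can be read, and the record stands as: the limit of > 150000 nM in this assay, at which 4 of the 4 values shown sit. The compounds shown leave open whether any aryl group on the triazole nitrogen would give a readable number in this assay.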